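Chloro Added to Compound 1: an Expected Outcome

The source may report more compounds than this note shows. Statements on the series, on what has been measured and on what is new or still open speak of the compounds shown alone.

Compound 1 `O=C(Nc1cccc(-n2cc(-c3ccncc3)c(-c3ccc(Cl)c(O)c3)n2)c1)Nc1cccc(C(F)(F)F)c1` was tested in a functional assay on SK-MEL-28 cells (Homo sapiens) for inhibition, read by sulforhodamine B assay, with a stated time of 48 h; on this read-out lower numbers stand for higher toxicity in this test and higher numbers for lower toxicity in this test. In this assay compound 1 gives only a limit of the assay, > 32500 nM, a case of the limit of > 32500 nM in this assay, at which 1 of the 2 values shown sits. Compound 2 `COc1cc(-c2nn(-c3cccc(NC(=O)Nc4cccc(C(F)(F)F)c4)c3)cc2-c2ccncc2)ccc1Cl` carries a methyl in place of hydrogen on an oxygen on an aromatic ring, and in this assay compound 2 gives 21100 nM. Going by the values given here, the step of an at least 1.5-fold lower number from compound 1 to compound 2 (0.18 log units; that floor lies within the scatter) is the only measured step available, and it concerns a different part of the shared core from the change now considered. Compound 3 `O=C(Nc1cccc(-n2cc(-c3ccncc3)c(-c3ccc(Cl)c(O)c3)n2)c1)Nc1ccc(Cl)c(C(F)(F)F)c1` differs from compound 1 by chloro in place of hydrogen on an aromatic carbon. Among the compounds with values here, no measured step touches this chloro addition, so the only footing is that compound 1 stands at a limit. Compound 3 is therefore expected to stay close to that limit, with an estimated step of an at least 1.0-fold lower number from compound 1 to compound 3 (0.03 log units; that floor lies within the scatter) that is not expected to reach beyond the scatter. The expected value for compound 3 in this assay is 30000 nM, within a range from 12000 nM to 70000 nM.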

Compound 3, concentration lethal to 50% of the cells: 12400 nM
For compound 3 the middle estimate is 2.4-fold (0.38 log units) above the measured one; low and high end bracket the measured number.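

In this assay, chloro on an aromatic carbon, ortho to the trifluoromethyl group and para to a large group, gives an at least 2.6-fold lower number from compound 1 to compound 3 (0.41 log units; beyond the scatter). This is the first change in the series shown with a step that reaches beyond the scatter, and thus the first sign that this position on the 3-(trifluoromethyl)phenyl ring can move the number toward higher toxicity in this test, whereas the floor of the step at the oxygen stayed within the scatter. Compound 1 stands at a limit of the assay, so the step gives only a floor and not its full size: the limit of > 32500 nM in this assay, at which 1 of the 3 values shown sits.

The compounds shown leave open whether this shift is particular to chloro or would also appear with fluoro, a nitrile or an amine at the same position. They also leave open whether chloro at this position would give a similar step on compound 2, which carries the methyl on the oxygen.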